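The source may report more compounds than this note shows. Statements on the series, on what has been measured and on what is new or still open speak of the compounds shown alone.

Compound 3 `Nc1scc(CN2CCN(c3cccc(F)c3F)CC2)c1C(=O)c1ccc(Cl)cc1` gives -13% in a functional assay on CHO cells with adenosine receptor A1 (Homo sapiens) as the target, read by cAMP accumulation and immunoassay, with a stated time of 6 min, tested at 0.01 uM (on this read-out higher numbers stand for a weaker effect at the one concentration tested and lower numbers for a stronger effect), the lowest of the three numbers in hand. Compound 1 `Nc1scc(CN2CCN(c3ccc(Cl)cc3F)CC2)c1C(=O)c1ccc(Cl)cc1` gives -9.2% and compound 2 `Nc1scc(CN2CCN(c3ccc(F)cc3F)CC2)c1C(=O)c1ccc(Cl)cc1` gives 0% in this assay. Compound 4 `Nc1scc(CN2CCN(c3c(F)cc(F)cc3F)CC2)c1C(=O)c1ccc(Cl)cc1` differs from compound 3 in one place: 2,4,6-trifluorophenyl in place of 2,3-difluorophenyl on an amine nitrogen in a ring. Two measured steps alter the same aryl group on the same ring nitrogen: a number 13 percentage points lower from compound 2 to compound 3 (beyond the scatter) and a number 3.8 percentage points lower from compound 1 to compound 3 (within the scatter). One is modest and beyond the scatter, the other within it, and all three compounds sit near zero, so swapping this aryl group has moved the number only a little in either direction. Compound 4 is therefore expected to show a step of a number 8 percentage points higher from compound 3 to compound 4 (within the scatter), staying within the scatter. Compound 4 is estimated at -5%, with a range from -20% to 10% in this assay.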

Compound 4, a percentage reported as activity, at one concentration (the size of the read-out at that concentration, not a potency): 4.2%
Compound 4: the middle estimate sits 9.2 percentage points below what was measured; the measured number falls inside the stated range.
By their numbers in this assay, from the lowest: compounds 3, 1, 2 and 4 (each within the scatter of the next, the first and the last beyond it).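

In this assay, 2,4,6-trifluorophenyl on the amine nitrogen in a ring gives a number 17.2 percentage points higher from compound 3 to compound 4 (beyond the scatter) and a number 13.4 percentage points higher from compound 1 to compound 4 (beyond the scatter), yet against the 2,4-difluorophenyl group the same aryl group gives only a number 4.2 percentage points higher from compound 2 to compound 4 (within the scatter) as fluoro replaces hydrogen on an aromatic carbon. The position therefore responds modestly to the choice of aryl group, with one added fluoro on compound 2 leaving the number within the scatter. Nothing measured accounts for these steps. As far as these compounds go, whether a methoxy group or a nitrile on this aryl ring would shift the number remains open, as does the effect of a cyclohexyl group in its place.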